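The compounds below may be only part of what the source reports. "The series", "measured", "known", "first", "only" and "open" are said of these compounds alone.

Three compounds share one core and differ only in the ring attached to it. Compound 1 `CCCCCc1c(C(C)C)nc(C(C)C)c(CO)c1-c1ccccc1F` gives 9000 nM in an assay on CHO cells for inhibition of Glucagon receptor (Homo sapiens); on this read-out higher numbers stand for weaker inhibition and lower numbers for stronger inhibition. Compound 2 `CCCCCc1c(C(C)C)nc(C(C)C)c(CO)c1-c1ccc(F)c(F)c1` gives 1100 nM, and compound 3 `CCCCCc1c(C(C)C)nc(C(C)C)c(CO)c1-c1ccccc1O` gives 500 nM, the lowest of the three numbers. The steps among them are an 8.2-fold lower number from compound 1 to compound 2 (0.91 log units; beyond the scatter), a 2.2-fold lower number from compound 2 to compound 3 (0.34 log units; beyond the scatter) and an 18-fold lower number from compound 1 to compound 3 (1.26 log units; beyond the scatter). Compound 4 `CCCCCc1c(C(C)C)nc(C(C)C)c(CO)c1-c1ccccc1N` carries amino in place of hydroxy on an aromatic carbon. Among the compounds with values here, of the measured steps only the one from compound 1 to compound 3 alters this same place, and no measured step exchanges hydroxy for amino; the entering group matches the leaving one in what that difference counts. A small step is therefore expected: a 1.4-fold higher number from compound 3 to compound 4 (0.15 log units; within the scatter). Compound 4 is estimated at 700 nM, within 200 nM to 3000 nM.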

Compound 4, half-maximal inhibitory concentration: 2300 nM
Compound 4: the middle estimate sits 3.3-fold (0.52 log units) below what was measured; the measured number falls inside the stated range.
By their numbers in this assay, from the lowest: compound 3; then compound 2; then compound 4; then compound 1.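

Hydroxy and amino count the same in heavy atoms, donors and acceptors, yet this exchange on the aromatic carbon gives a 4.6-fold higher number from compound 3 to compound 4 (0.66 log units; beyond the scatter), so matching counts do not make the two groups interchangeable here. The amino group still compares well with fluoro, with a 3.9-fold lower number from compound 1 to compound 4 (0.59 log units; beyond the scatter), while the change from the 3,4-difluorophenyl ring to the 2-aminophenyl ring gives a 2.1-fold higher number from compound 2 to compound 4 (0.32 log units; beyond the scatter). Nothing available explains why hydroxy and amino differ at this place. On these data alone, whether a methoxy group or a carboxylic acid at this place would fall nearer compound 3 or compound 4 remains open.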